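The source may hold more compounds than are shown below. What is called first, only, known or untested is meant among the compounds shown, and "the series" means these compounds.

Compound 2 `CCOc1ccc(S(=O)(=O)N(C)C)cc1-c1ncc(C(=O)O)c(=O)[nH]1` gives only a limit in a functional assay on the whole organism (strain Sprague-Dawley) for inhibition, with Rattus norvegicus as the target, with a stated time of 10 min (a lower number here means that less compound is needed, a higher number that more compound is needed for the effect), > 50 mg/kg. Compound 1 `CCOc1ccccc1-c1ncc(C(=O)O)c(=O)[nH]1` gives 0.5 mg/kg, and the step of an at least 100-fold higher number from compound 1 to compound 2 (2.00 log units; beyond the scatter) is large. Compound 3 `CCOc1ccc(S(=O)(=O)N(C)C(C)C)cc1-c1ncc(C(=O)O)c(=O)[nH]1` also sits at a limit, > 10 mg/kg. The step of an at least 20-fold higher number from compound 1 to compound 3 (1.30 log units; beyond the scatter) is large as well, while a step that the two limits leave unreadable from compound 2 to compound 3 cannot be read, since both ends are limits (the limit of > 10 mg/kg in this assay, at which 1 of the 3 values shown sits, (the limit of > 50 mg/kg in this assay, at which 1 of the 3 values shown sits)). Compound 4 `CCOC(=O)c1cnc(-c2cc(S(=O)(=O)N(C)C)ccc2OCC)[nH]c1=O` carries ethyl in place of hydrogen on an oxygen next to a carbonyl group. Going by the values given here, every measured step concerns the sulfamoyl group, none the carboxy group, so no measured step bears on this change. With compound 2 already at a limit, a limit is the likeliest outcome again. Compound 4 is therefore expected at 50 mg/kg (10 mg/kg to 250 mg/kg). For compound 4 this estimate means a number no higher from compound 2 to compound 4 (the limit leaves the size open).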

Compound 4, dose for 50% inhibition: 50 mg/kg
Compound 4: the middle estimate sits on the measured number at the digits printed; the range from low to high includes it.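

In this assay compound 4 gives a readable number, 50 mg/kg, so with the dimethylsulfamoyl group present a free carboxy group is not needed for a measured dose. Compound 2 gives only a limit, > 50 mg/kg. The change from carboxy to ethoxycarbonyl gives a number no higher from compound 2 to compound 4 (the limit leaves the size open), and its size cannot be read because one end is a limit: the limit of > 50 mg/kg in this assay, at which 1 of the 4 values shown sits.

From the compounds shown here alone, whether a longer chain on that oxygen, or a primary amide in place of the ester, would give a lower dose stays open. So does the effect of ethoxycarbonyl on the core of compound 1, without a sulfamoyl group.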